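Swapping dimethylcarbamoyl for 2-methyl-1,3-thiazol-4-yl

The compounds below may be only part of what the source reports. "The series", "measured", "known", "first", "only" and "open" are said of these compounds alone.

Going by the values given here, in an ADME assay on the whole organism (strain 129/SvEvBrd x C57BL/6) for metabolic stability, with Mus musculus as the target (a higher number here means that the compound lasts longer, a lower number that the compound disappears faster), compound 1 `CN(C)C(=O)c1nc([C@@H](O)[C@H](O)[C@H](O)CO)c[nH]1` gives 4 h and holds the higher of the two numbers so far. Compound 2 `OC[C@@H](O)[C@@H](O)[C@H](O)c1c[nH]c(C(F)(F)C(F)(F)F)n1` gives 1.7 h here, a gap beyond the scatter. Compound 3 `Cc1nc(-c2nc([C@@H](O)[C@H](O)[C@H](O)CO)c[nH]2)cs1` carries 2-methyl-1,3-thiazol-4-yl in place of dimethylcarbamoyl on an aromatic carbon of the shared core. Among the compounds with values here, no measured pair shows a change at this place, so the guidance is thin. A fall no larger than the scatter is expected in this assay (a 1.6-fold lower number from compound 1 to compound 3 (0.20 log units; within the scatter)). For compound 3 the estimated half-life is 2.5 h (range 1 h to 6 h).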

Compound 3, half-life: 2.1 h
Estimate against measurement, compound 3: 1.2-fold (0.08 log units) above, and the stated range covers the measured number.
By their numbers in this assay, from the lowest: compounds 2, 3 and 1 (each within the scatter of the next, the first and the last beyond it).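

In this assay, the position on an aromatic carbon between two ring nitrogen atoms now has its first reading, with a 1.9-fold lower number from compound 1 to compound 3 (0.28 log units; within the scatter) as 2-methyl-1,3-thiazol-4-yl replaces dimethylcarbamoyl. An aromatic ring can therefore take the place of this group with no change in half-life beyond the scatter. No measurement on hand bears on why the half-life stays within the scatter.

A single change at this position cannot show how much the ring and its methyl each contribute. From the compounds shown here alone, how a carboxylic acid, a primary amine or an unsubstituted thiazole would behave here remains open.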